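Aryl swap on the four-membered core: nitro for chloro

A few compounds are considered here, and "the series" means these few. Any claim that something is new, unique, unknown or untested is made for them only; others in the source may bear on it.

For the measured compounds named here, compound 1 `COC(=O)/C(=C/c1ccccc1)CN1C(=O)[C@@H](OC)[C@H]1c1ccc(Cl)cc1` gives 37900 nM in an ADME assay on cells (Epithelial cell, Homo sapiens) for antiproliferative activity, read by MTT assay, with a stated time of 48 h (a lower number here means a stronger inhibitor, a higher number a weaker inhibitor), one of only two numbers recorded; the other, compound 3 `COC(=O)/C(=C/c1ccccc1)CN1C(=O)[C@@H](OC)[C@H]1c1cccc(F)c1` at 38500 nM, sits within the scatter of it. Compound 2 `CO[C@@H]1C(=O)N(C/C(C#N)=C/c2ccccc2)[C@@H]1c1ccc(Cl)cc1Cl` gives only a limit of the assay, > 100000 nM. Going by the values given here, the single measured step on the aryl group, a 1.0-fold higher number from compound 1 to compound 3 (0.01 log units; within the scatter), moved nothing beyond the scatter. Compound 4 `COC(=O)/C(=C/c1ccccc1)CN1C(=O)[C@@H](OC)[C@H]1c1cccc([N+](=O)[O-])c1` differs from compound 1 by 3-nitrophenyl in place of 4-chlorophenyl on a saturated ring carbon. Among the compounds with values here, no measured step covers a 3-nitrophenyl on this position, so the 3-fluorophenyl step is the only guide; on that basis compound 4 is expected to give 40000 nM (range 15000 nM to 100000 nM). The expected step is a 1.1-fold higher number from compound 1 to compound 4 (0.02 log units; within the scatter), within the scatter.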

Compound 4, half-maximal inhibitory concentration: "not toxic" (no number reported)
No number was reported for compound 4, and the estimate cannot be compared.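

For the compounds shown here, compound 4 is reported in this assay only as "not toxic", without a number, so no step from compound 1 to compound 4 can be read. The compounds shown leave open whether compound 4 lies near the assay's ceiling: the limit of > 100000 nM in this assay, at which 1 of the 4 values shown sits.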